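Series notes: aryl swap on the ring nitrogen, compound 3

The compounds below may be only part of what the source reports. "The series", "measured", "known", "first", "only" and "open" are said of these compounds alone.

Going by the values given here, compound 2 `Nc1scc(CN2CCN(c3c(F)cccc3F)CC2)c1C(=O)c1ccc(Cl)cc1` is the lower of the two numbers so far in a functional assay on CHO cells with adenosine receptor A1 (Homo sapiens) as the target, read by cAMP accumulation and immunoassay, with a stated time of 6 min, tested at 0.1 uM; on this read-out higher numbers stand for a weaker effect at the one concentration tested and lower numbers for a stronger effect. In this assay, among the compounds with values here, compound 2 gives -23%, while compound 1 `Nc1scc(CN2CCN(c3cccnc3)CC2)c1C(=O)c1ccc(Cl)cc1` gives 3.4%; the one measured step, a number 26.4 percentage points lower from compound 1 to compound 2 (beyond the scatter), runs in favour of a stronger effect for compound 2.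

Compound 3 `Nc1scc(CN2CCN(c3ccc(F)c(Cl)c3)CC2)c1C(=O)c1ccc(Cl)cc1` is not yet measured. Against compound 2 it changes (3-chloro-4-fluorophenyl in place of 2,6-difluorophenyl on an amine nitrogen in a ring). The step from compound 1 to compound 2 is the only one that touches the same place, the group on the ring nitrogen, and it was modest in size. It does not, however, compare two halogenated phenyl groups with each other, so the direction of the step to compound 3 is open. The expectation is that the change to compound 3 moves the read-out by a number 15 percentage points higher from compound 2 to compound 3 (beyond the scatter), a small step, quite possibly within the scatter, with a slight lean back toward a weaker effect. For compound 3 the estimate in this assay is -8%, with a range from -35% to 20%.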

Compound 3, a percentage reported as activity, at one concentration (the size of the read-out at that concentration, not a potency): -21%
Compound 3: the middle estimate sits 13 percentage points above what was measured, and the stated range covers the measured number.
By their numbers in this assay, from the lowest: compounds 2 and 3 (each within the scatter of the next); then compound 1.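

In this assay, the two halogenated phenyl groups cannot be told apart at this position: a number 2 percentage points higher from compound 2 to compound 3 (within the scatter) leaves 3-chloro-4-fluorophenyl and 2,6-difluorophenyl reading alike, even though the halogens differ in kind and in their placing on the phenyl ring. Going by these compounds alone, compound 2 alone could not show whether its distance from compound 1 belonged to that particular halogen pattern, but a number 24.4 percentage points lower from compound 1 to compound 3 (beyond the scatter) now runs the same way as a number 26.4 percentage points lower from compound 1 to compound 2 (beyond the scatter) and is also beyond the scatter, so in these three compounds both halogenated phenyl groups stand apart from pyridin-3-yl, with no compound going against this. Nothing measured here accounts for these readings.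

From the compounds shown here alone, it remains open whether the halogens matter at all on the amine nitrogen in the ring, since an unsubstituted phenyl, a methoxyphenyl or a saturated cyclohexyl group in the same place would separate the halogens from the aromatic ring that carries them. A read-out at one concentration also gives no potency, so the likeness of compound 2 and compound 3 may not extend across a range of concentrations.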